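A few compounds are considered here, and "the series" means these few. Any claim that something is new, unique, unknown or untested is made for them only; others in the source may bear on it.

Among the measured compounds shown here, in a functional assay on HL-60 cells (Homo sapiens) for inhibition, read by MTT assay, with a stated time of 72 h (on this read-out higher numbers stand for weaker inhibition and lower numbers for stronger inhibition), compound 1 (`CCc1nc(-c2ccccc2Cl)c(C(=O)N2CCN(c3cccc(Cl)c3)CC2)o1`) gives 98.9 nM, the only number available in this small set. Compound 2 (`CCCc1nc(-c2ccc(OC)cc2)c(C(=O)N2CCN(c3cccc(Cl)c3)CC2)o1`) gives "not active" (no number reported), so it has no single number, and its standing can be told only as that outcome. Compound 3 (`CCc1nc(-c2ccc(OC)cc2)c(C(=O)N2CCN(c3cccc(Cl)c3)CC2)o1`) has yet to be measured in this assay. The structural change is small: hydrogen in place of methyl on a saturated chain carbon, two bonds along the chain from an aromatic carbon. In words, hydrogen stands in place of methyl on a saturated chain carbon, two bonds along the chain from an aromatic carbon, which turns propyl into ethyl. For the measured compounds named here, no measured step of this kind is available, and the result for compound 2 offers no number to start from, so the size of the step cannot be read from the data. A modest move towards stronger inhibition is expected, perhaps enough to yield a measurable number, although a second result without a number remains quite possible. Weaker inhibition than compound 1 at 98.9 nM is the expected outcome. For compound 3 the estimated value in this assay is 1000 nM, with an expected range from 150 nM to 7000 nM.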

Compound 3, half-maximal inhibitory concentration: > 1000 nM
Compound 3 ended at the assay's limit; the forecaster's own chance of this, stated with the estimate: 40%; the middle value sits exactly at the limit.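

In this assay compound 3 gives > 1000 nM, which is a limit of the assay and not a number: the limit of > 1000 nM in this assay, at which 1 of the 3 values shown sits. Replacing propyl with ethyl on a saturated chain carbon therefore still yields no number on the 4-methoxyphenyl compounds, and the step between compound 2 and compound 3 cannot be read, as neither end has a number. With ethyl common to both compounds, the change from 2-chlorophenyl to 4-methoxyphenyl on an aromatic carbon can now be sized, and it gives an at least 10-fold higher number from compound 1 to compound 3 (1.00 log units; beyond the scatter), a step beyond the scatter that the earlier pair, which differed in more than one place, could not provide.

On these data alone, it remains open whether 2-chlorophenyl would keep a measurable number with propyl in place of ethyl, and thus whether the chain matters at all once that aryl group is present. As far as these compounds go, it is also open whether the loss follows from the methoxy group itself or from its place on the ring, a question that an amine or a hydroxyl on the phenyl ring, or a 2-methoxyphenyl group, could help to answer.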